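This account rests on a few compounds, and the source may have more. Where it says the series, first, only, none or still open, it means among the compounds named here.

Measured so far in an ADME assay on MRC5 cells (Homo sapiens) for cytotoxicity, read by resazurin assay, with a stated time of 72 h; a lower number here means a stronger inhibitor, a higher number a weaker inhibitor:

Compound 1 `CN(CC1CCn2cc([N+](=O)[O-])nc2O1)c1ccc(OC(F)(F)F)cc1` gives >= 40000 nM, which is a limit of the assay and not a number.
Compound 2 `CN(CC1(C)CCn2cc([N+](=O)[O-])nc2O1)c1ccc(OC(F)(F)F)cc1` gives >= 40000 nM, again a limit of the assay.
Compound 3 `O=C(NCC1CCn2cc([N+](=O)[O-])nc2O1)c1ccc(OC(F)(F)F)cc1` gives >= 40000 nM, also a limit of the assay.

Compound 1 and compound 2 share a core and differ in one place: methyl in place of hydrogen on a saturated ring carbon. Because both readings sit at the limit of >= 40000 nM in this assay, at which 3 of the 3 values shown sit, the step that the two limits leave unreadable from compound 1 to compound 2 cannot be read; it is only known that neither compound reached a measurable strength in this assay. Compound 3 carries a different core, and the difference between the two cores is not broken down here; its own reading is likewise a limit.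

Compound 4 `CC1(CNC(=O)c2ccc(OC(F)(F)F)cc2)CCn2cc([N+](=O)[O-])nc2O1` has not yet been measured in this assay. It differs from compound 3 by the same change that turns compound 1 into compound 2: methyl in place of hydrogen on a saturated ring carbon. Since that change gave no readable step in the first pair, and since compound 3 itself sits at the limit, the expectation is that the step of a number no higher from compound 3 to compound 4 (the limit leaves the size open) will again stay unreadable, with compound 4 most likely reported as a limit. The estimate for compound 4 in this assay is therefore 40000 nM, with a plausible range from 30000 nM to 80000 nM. This expectation rests on compound 3, which gives >= 40000 nM, a limit of the assay. It also rests on the pair of limits at the limit of >= 40000 nM in this assay, at which 3 of the 3 values shown sit.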

Compound 4, half-maximal inhibitory concentration: >= 40000 nM
Compound 4: no number, only a limit; the forecaster's own chance of this, stated with the estimate: 85%; the middle value lies on the limit itself.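

No step can be read from compound 3 to compound 4, since each gives only a limit of the assay, and the added methyl therefore shows no measurable effect, because all the readings sit at one ceiling: the limit of >= 40000 nM in this assay, at which 4 of the 4 values shown sit.

The compounds shown leave open where any of them would give an actual number in this assay and whether methyl in place of hydrogen changes that number at all.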